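Swapping one ring substituent in a seizure model

A few compounds are considered here, and "the series" means these few. Any claim that something is new, unique, unknown or untested is made for them only; others in the source may bear on it.

Compound 1 `O=[N+]([O-])c1ccc(/C=N/Cc2cccnc2)cc1` and compound 2 `C(=N/Cc1cccnc1)\c1ccccc1` share a core and differ only at one aromatic carbon. In a functional assay on the whole organism (strain Swiss albino) with Mus musculus as the target, in the maximal electroshock model, with a stated time of 0.5 h (a higher number here means that more compound is needed for the effect, a lower number that less compound is needed), compound 1 gives 100 mg/kg, and compound 2 gives 100 mg/kg. Among the compounds with values here, the single comparison available, no change at the digits printed from compound 1 to compound 2 (within the scatter), is the replacement of hydrogen for nitro on an aromatic carbon, and it left the minimum effective dose where it was. Compound 2 therefore stands level with compound 1 on the numbers at hand.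

The next compound, compound 3 `Clc1ccc(/C=N/Cc2cccnc2)cc1`, differs from compound 2 by chloro in place of hydrogen on an aromatic carbon. This change sits at the same aromatic carbon where nitro was exchanged for hydrogen before. Within the data shown here, the only step bearing on it, no change at the digits printed from compound 1 to compound 2 (within the scatter), showed no movement beyond the usual scatter, so a small group entering at that position is not expected to move this assay much either. Compound 3 is therefore expected to show a step of no change at the digits printed from compound 2 to compound 3 (within the scatter) relative to compound 2, that is, nothing beyond the scatter. The estimate for compound 3 in this assay is 100 mg/kg, with a range from 50 mg/kg to 200 mg/kg.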

Compound 3, minimum effective dose: 100 mg/kg
For compound 3 middle estimate and measured number coincide at the digits printed; the measured number falls inside the stated range.
By their numbers in this assay, from the lowest: compounds 1, 2 and 3 (each within the scatter of the next).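

In this assay, placing chloro on this aromatic carbon gives no change at the digits printed from compound 2 to compound 3 (within the scatter), and exchanging nitro for chloro at the same carbon gives no change at the digits printed from compound 1 to compound 3 (within the scatter). The earlier pair showed only that nitro and hydrogen could not be told apart here; with chloro, three different occupants of this carbon, para to a group of 9 heavy atoms, now cannot be told apart in this whole-animal test, and the second step compares two substituents directly rather than a substituent with bare hydrogen. Nothing available explains why the minimum effective dose stays level across these three compounds.

As far as these compounds go, since all three compounds stand level, the series does not yet contain a change at this carbon that moves the dose in either direction, so it is unknown whether this carbon can influence the result at all. An amine, a carboxylic acid or a longer chain such as butyl at this carbon remains untested in the compounds shown, as do changes elsewhere in the shared core, and any of these could reveal whether the level reading holds beyond these three groups.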